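Removing a Ring Hydroxyl From a Weak Antiproliferative

The source may hold more compounds than are shown below. What is called first, only, known or untested is meant among the compounds shown, and "the series" means these compounds.

Compound 1 `COC(=O)[C@]1(Cc2ccc3c(c2)C[C@H](O)C(C)(C)O3)OC(=O)C(O)=C1c1ccc(O)cc1` gives in a functional assay on PANC-1 cells (Homo sapiens) for antiproliferative activity, read by CCK-8 assay, with a stated time of 24 h (a higher number here means a weaker inhibitor, a lower number a stronger inhibitor), a value of > 20000 nM, which is a limit of the assay rather than a number. Compound 2 `COC(=O)[C@]1(Cc2ccc(O)c(C[C@@H](O)C(C)C)c2)OC(=O)C(O)=C1c1ccc(O)cc1` likewise returns a limit in this assay, > 20000 nM. Compound 1 thus stands at the limit of > 20000 nM in this assay, at which 2 of the 2 values shown sit, where every value shown sits. Compound 3 `COC(=O)[C@]1(Cc2ccc3c(c2)CCC(C)(C)O3)OC(=O)C(O)=C1c1ccc(O)cc1` differs from compound 1 only by hydrogen in place of hydroxy on a saturated ring carbon. Because both measured compounds sit at the limit of > 20000 nM in this assay, at which 2 of the 2 values shown sit, the step from compound 1 to compound 3 in this assay is expected to stay within the scatter, with no direction. Compound 3 is therefore expected to give 30000 nM, with a range from 10000 nM to 100000 nM. The expected step is a step that the limit leaves unreadable from compound 1 to compound 3.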

Compound 3, half-maximal inhibitory concentration: > 20000 nM
Compound 3 gave a limit, no number; the forecaster's own chance of this, stated with the estimate: 85%; the middle value lies beyond the limit too.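

Among these compounds, compound 1 and compound 3 each give only a limit in this assay, and no step between them can be read. On these data alone, whether the hydroxy on the saturated ring carbon matters for activity remains open.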